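Notes on the lipid chain in compounds 1 to 3

The source may report more compounds than this note shows. Statements on the series, on what has been measured and on what is new or still open speak of the compounds shown alone.

Compound 1 `CCCCCCCCCCCCCCCCNC(=O)[C@H](O)CO[C@H]1O[C@H](CO)[C@@H](O)[C@H](O)[C@H]1NC(C)=O` and compound 2 `CCCCCCCCCCCCCCCCCNC(=O)[C@H](O)CO[C@H]1O[C@H](CO)[C@@H](O)[C@H](O)[C@H]1NC(C)=O` share one core and differ only in the chain: compound 2 carries a methyl in place of hydrogen on a saturated chain carbon, ten or more bonds along the chain from an amide-type nitrogen. In a functional assay on SK-HEP1 cells (Homo sapiens) for cytotoxicity, read by sulforhodamine B assay, with a stated time of 72 h (on this read-out higher numbers stand for weaker inhibition and lower numbers for stronger inhibition), compound 1 reaches only the limit > 10000 nM. In this assay compound 2 likewise gives only the limit > 10000 nM. The step that the two limits leave unreadable from compound 1 to compound 2 is thus unreadable, as the limit of > 10000 nM in this assay, at which 2 of the 2 values shown sit, records. Compound 2 stands at the limit of the read-out, with no number attached to it.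

Compound 3 `CCCCCC/C=C\CCCCCCCCNC(=O)[C@H](O)CO[C@H]1O[C@H](CO)[C@@H](O)[C@H](O)[C@H]1NC(C)=O` differs from compound 2 by a group of 8 heavy atoms (8 carbon; no ring) in place of a group of 9 heavy atoms (9 carbon; no ring), on a saturated chain carbon, eight bonds along the chain from an amide-type nitrogen. Going by the values given here, no measured step bears on this change: the only step between measured compounds, a step that the two limits leave unreadable from compound 1 to compound 2, is unreadable, and every value shown is a limit. The expectation therefore rests on compound 2 alone. Compound 3 is expected to sit at the limit as well, the expected step being a step that the limit leaves unreadable from compound 2 to compound 3, not readable beyond the scatter. For compound 3 the estimate is 15000 nM, with a range from 5000 nM to 50000 nM, most likely reported again only as a limit.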

Compound 3, half-maximal inhibitory concentration: > 10000 nM
Compound 3: a limit, no number; the forecaster's own chance of this, stated with the estimate: 85%; the middle value does not contradict the limit.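

No step among compound 1, compound 2 and compound 3 can be read, as all three stop at the same limit and none carries a number: the limit of > 10000 nM in this assay, at which 3 of the 3 values shown sit.

The compounds shown leave open whether the change of chain has any bearing on this read-out, and where the true value of each compound lies.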